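Halogenated benzyl triazoles on a chromone ether core

This account rests on a few compounds, and the source may have more. Where it says the series, first, only, none or still open, it means among the compounds named here.

In a functional assay on A549 cells (Homo sapiens) for cytotoxicity, read by MTT assay, with a stated time of 48 h (on this read-out higher numbers stand for weaker inhibition and lower numbers for stronger inhibition), compound 1 `Cc1ccc(Cn2cc(COc3ccc4c(=O)ccoc4c3)nn2)cc1` gives 50700 nM. Compound 2 `O=c1ccoc2cc(OCc3cn(Cc4ccc(Cl)cc4)nn3)ccc12` reaches only (the limit of > 100000 nM in this assay, at which 1 of the 2 values shown sits), so for compound 2 this assay yields a limit, > 100000 nM, and no number. Among the measured compounds shown here, the one measured step, an at least 1.9-fold higher number from compound 1 to compound 2 (0.29 log units; that floor lies within the scatter), bears only loosely on the next change. Compound 3 `O=c1ccoc2cc(OCc3cn(Cc4cccc(Br)c4)nn3)ccc12` differs from compound 2 by 3-bromophenyl in place of 4-chlorophenyl on a saturated chain carbon bound to an aromatic nitrogen. Compound 3 is therefore expected to stay near the limit, with an estimated step of a number no higher from compound 2 to compound 3 (the limit leaves the size open). The estimate for compound 3 is 100000 nM, ranging from 35000 nM to 300000 nM.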

Compound 3, half-maximal inhibitory concentration: > 100000 nM
Compound 3 was reported as a limit (the forecaster's own chance of this, stated with the estimate: 60%); the middle value lies on the limit itself.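

With 3-bromophenyl in place of 4-chlorophenyl on a saturated chain carbon bound to an aromatic nitrogen, compound 3 also ends at a limit and not at a number: the limit of > 100000 nM in this assay, at which 2 of the 3 values shown sit.

The step between the two limits cannot be read, so these two halogenated groups cannot be ranked against each other. Among the compounds shown here, the only reading is that 3-bromophenyl in place of 4-methylphenyl gives an at least 1.9-fold higher number from compound 1 to compound 3 (0.29 log units; that floor lies within the scatter).

Still open, going by these compounds, is whether an amine or a carboxylic acid in place of the halogen would give a readable number in this assay.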